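The source may report more compounds than this note shows. Statements on the series, on what has been measured and on what is new or still open speak of the compounds shown alone.

Of the compounds shown here, two have been measured in a functional assay on HT-29 cells (Homo sapiens) for inhibition, read by MTT assay, with a stated time of 72 h; a lower number here means a stronger inhibitor of growth, a higher number a weaker inhibitor of growth. Compound 1, `N#C/C(=C\c1c(F)c(F)c(F)c(F)c1F)C(=O)c1ccc[nH]1`, gives 224000 nM in this assay, a weak effect. Compound 2, `COc1ccc(CNC(=O)/C(C#N)=C/c2ccc[nH]2)cc1`, shares the amide and nitrile chain but carries a different ring at each end. In this assay compound 2 reaches only a limit, > 50000 nM, which is not a number. That is where compound 2 stands: at the limit of > 50000 nM in this assay, at which 1 of the 2 values shown sits, and nothing finer than that floor is known for it.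

Compound 3, `COc1ccc(CNC(=O)/C(C#N)=C/c2ccco2)cc1`, differs from compound 2 in one place: furan-2-yl in place of 1H-pyrrol-2-yl on a double-bonded chain carbon bound to a double-bonded chain carbon. Among the measured compounds shown here, no measured pair shows the effect of exactly this exchange, and the size of the step cannot be read from the data. The expectation is a step with no clear direction and not larger than the scatter, and compound 2 already sitting at its limit suggests compound 3 will land near that limit as well.

Compound 3 is therefore expected to give about 80000 nM in this assay, with a range from 25000 nM to 300000 nM. The step this expectation implies is estimated as a step that the limit leaves unreadable from compound 2 to compound 3.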

Compound 3, concentration for 50% growth inhibition: 22000 nM
For compound 3 the middle estimate is 3.6-fold (0.56 log units) above the measured one; measured number outside the range, below it.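

In this assay, furan-2-yl in place of 1H-pyrrol-2-yl on a double-bonded chain carbon bound to a double-bonded chain carbon gives an at least 2.2-fold lower number from compound 2 to compound 3 (0.35 log units; beyond the scatter). Among the compounds shown here, this is the first readable sign that this place matters: both rings are five-membered and aromatic, with 5 heavy atoms and 1 hetero atom, yet exchanging the nitrogen of one for the oxygen of the other is enough to move the result beyond the usual scatter. The real step may be larger, because the value for compound 2 is only a limit of the assay, so the size given is a minimum: the limit of > 50000 nM in this assay, at which 1 of the 3 values shown sits.

For the compounds shown here, the single pair cannot tell whether the step follows the loss of the hydrogen-bond donor, the gain of the hydrogen-bond acceptor, or some other difference between the two rings. Going by these compounds, how a thiophen-2-yl ring, with sulfur as its hetero atom, would behave at this place remains open, as does whether the same exchange would give a similar step with a different group on the amide.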